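This account rests on a few compounds, and the source may have more. Where it says the series, first, only, none or still open, it means among the compounds named here.

Measured in a functional assay on MCF7 cells (Homo sapiens) for antiproliferative activity, read by MTT assay, with a stated time of 72 h; on this read-out higher numbers stand for weaker inhibition and lower numbers for stronger inhibition:
- compound 1 `COc1cc2c(Nc3ccc(C#N)cc3)ncnc2cc1OCCCN(C)Cc1ccccc1`: > 100000 nM (a limit of the assay)
- compound 2 `CCN1CCN(CCCOc2cc3ncnc(Nc4ccc(C#N)cc4)c3cc2OC)CC1`: 29900 nM
- compound 3 `COc1cc2c(Nc3ccc(C#N)cc3)ncnc2cc1OCCCN1CCN(c2ccncc2)CC1`: 22900 nM

Only compound 2 and compound 3 have actual numbers in this assay, and these two do not separate: a 1.3-fold lower number from compound 2 to compound 3 (0.12 log units; within the scatter). Compound 1 is represented only by a limit.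

The next compound, compound 4 `CCN1CCN(CCCOc2cc3ncnc(Nc4ccccc4C#N)c3cc2OC)CC1`, keeps the chain of compound 2 and changes elsewhere: 2-cyanophenyl in place of 4-cyanophenyl on a nitrogen on an aromatic ring. In words, 2-cyanophenyl stands in place of 4-cyanophenyl on a nitrogen on an aromatic ring.

The measured steps bear on this only indirectly, since all of them alter the amine on the saturated chain and none moves the nitrile. Two are beyond the scatter, an at least 3.3-fold lower number from compound 1 to compound 2 (0.52 log units; beyond the scatter) and an at least 4.3-fold lower number from compound 1 to compound 3 (0.64 log units; beyond the scatter), and both start from a limit. The third, between the two numbered compounds, stays within the scatter. Going by the values given here, no measured step therefore gives a size for this change, and the estimate stays anchored on compound 2 at 29900 nM, with a wide margin in both directions. The expected step is a 1.0-fold higher number from compound 2 to compound 4 (0.00 log units; within the scatter), which means no change beyond the scatter is expected. For compound 4 the estimated value is 30000 nM, with an expected range of 9000 nM to 100000 nM.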

Compound 4, half-maximal inhibitory concentration: 9070 nM
Compound 4: middle estimate off by 3.3-fold (0.52 log units), on the high side, and the stated range covers the measured number.
By their numbers in this assay, from the lowest: compound 4; then compounds 3 and 2 (each within the scatter of the next). At a limit, above all of these: compound 1.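

In this assay, going by these compounds alone, the earlier compounds differ only in the amine on the saturated chain, and the one step between two actual numbers stays within the scatter. Within the data shown here, putting 2-cyanophenyl in place of 4-cyanophenyl on a nitrogen on an aromatic ring gives a 3.3-fold lower number from compound 2 to compound 4 (0.52 log units; beyond the scatter) and is the first step beyond the scatter in which both ends are actual numbers. The two groups count the same atoms, the same ring and the same hydrogen-bond acceptor, so this step records only how the same atoms are joined, and nothing measured here gives a reason for it.

On these data alone, it remains open how 3-cyanophenyl, unsubstituted phenyl or 2-chlorophenyl on the same nitrogen would read, and so whether the nitrile itself is needed for the lower number seen with compound 4. As far as these compounds go, it is equally open whether 2-cyanophenyl would lower the number by a similar step when paired with the 4-(pyridin-4-yl)piperazin-1-yl chain of compound 3 or with a longer chain carrying 4-ethylpiperazin-1-yl.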